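Chloro in Place of Hydrogen on the Core of Compound 2

This account rests on a few compounds, and the source may have more. Where it says the series, first, only, none or still open, it means among the compounds named here.

Going by the values given here, compound 2 `c1cncc(N2CCCNCCC2)c1` gives 0.9 nM in an assay (strain Wistar) for binding affinity to Neuronal acetylcholine receptor; alpha4/beta2 (Rattus norvegicus) (a higher number here means a weaker inhibitor, a lower number a stronger inhibitor), one of only two numbers recorded so far, and its single neighbour, compound 1 `CCCCOc1cncc(N2CCCNCCC2)c1`, which carries a butoxy group on the shared core, gives 1.8 nM. The step of a 2.0-fold lower number from compound 1 to compound 2 (0.30 log units; within the scatter) lies within the scatter, so the two compounds cannot be told apart on this assay. Compound 3 `Clc1cncc(N2CCCNCCC2)c1` differs from compound 2 by chloro in place of hydrogen on an aromatic carbon. Among the compounds with values here, the only measured step that bears on this position is the one between compound 1 and compound 2, where exchanging butoxy for hydrogen left the number within the scatter. A small group entering at the same place is therefore expected to leave the number within the scatter as well, the expected step being a 1.1-fold higher number from compound 2 to compound 3 (0.05 log units; within the scatter). Compound 3 is estimated at 1 nM, with a range from 0.3 nM to 3.5 nM.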

Compound 3, half-maximal inhibitory concentration: 2 nM
The estimate for compound 3 lay 2.0-fold (0.30 log units) below the measured number, and the stated range covers the measured number.
By their numbers in this assay, from the lowest: compounds 2, 1 and 3 (each within the scatter of the next, the first and the last beyond it).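

In this assay, going by these compounds alone, chloro in place of hydrogen gives the first step at this position that lies beyond the scatter, a 2.2-fold higher number from compound 2 to compound 3 (0.35 log units; beyond the scatter), although the step is modest. Chloro in place of butoxy, by contrast, gives a 1.1-fold higher number from compound 1 to compound 3 (0.05 log units; within the scatter), so compound 1 and compound 3 cannot be told apart, and of the three groups at this aromatic carbon only hydrogen and chloro are separated, while butoxy lies within the scatter of both. No measurement at hand accounts for the step from hydrogen to chloro. The compounds shown leave open how this position responds to an amine, a carboxylic acid or a fluoro group. They also leave open whether a chain longer than butoxy would stay within the same narrow band of numbers.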